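The compounds below may be only part of what the source reports. "The series", "measured", "known", "first", "only" and "open" are said of these compounds alone.

Compound 1 `COC[C@H]1C[C@@](CC(C)C)(C(=O)O)N(C(=O)c2ccc(C(C)(C)C)c(OC)c2)[C@H]1[C@H]1COC(=O)O1` is the starting point of this comparison. In an ADME assay on Huh-5-2 cells (Homo sapiens) for cytotoxicity, with a stated time of 3 days (a lower number here means that less compound is tolerated, a higher number that more compound is tolerated), compound 1 gives > 120000 nM, which is a limit of the assay rather than a measured number. Compound 2 `COC[C@H]1C[C@@](CC(C)C)(C(=O)O)N(C(=O)c2ccc(C(C)(C)C)c(OC)c2)[C@H]1COC(C)=O` is a measured analogue. In this assay compound 2 gives > 120000 nM, again a limit of the assay. Compound 3 `COC[C@H]1C[C@@](CC(C)C)(C(=O)O)N(C(=O)c2ccc(C(C)(C)C)c(OC)c2)[C@H]1CN=[N+]=[N-]` is a further analogue. In this assay compound 3 gives > 120000 nM, likewise a limit of the assay. None of the steps among these three can be sized: a step that the two limits leave unreadable from compound 1 to compound 2, a step that the two limits leave unreadable from compound 1 to compound 3 and a step that the two limits leave unreadable from compound 2 to compound 3. What all three share is the limit of > 120000 nM in this assay, at which 3 of the 3 values shown sit. Compound 4 `COC[C@H]1C[C@@](CC(C)C)(C(=O)O)N(C(=O)c2ccc(C(C)(C)C)c(OC)c2)[C@H]1CNC(C)=O` has not yet been measured in this assay. It differs from compound 1 in one place: acetamidomethyl in place of 2-oxo-1,3-dioxolan-4-yl on a saturated ring carbon. Every measured step here is hidden behind the limit, so no step can be read against this change. The step that the limit leaves unreadable from compound 1 to compound 4 is expected to leave compound 4 at the same limit. Compound 4 is therefore estimated at 150000 nM, with a range from 90000 nM to 300000 nM.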

Compound 4, half-maximal cytotoxic concentration: > 120000 nM
Compound 4 gave a limit, no number; the forecaster's own chance of this, stated with the estimate: 85%; the middle value is on the limit's open side.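

In this assay compound 4 gives > 120000 nM as a limit of the assay, so the steps to it from compound 1, compound 2 and compound 3 cannot be read. The compounds shown leave open at what concentration any of the four becomes cytotoxic, and whether they differ from one another.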